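Moving the chlorine on a pyridinyl ether

This account rests on a few compounds, and the source may have more. Where it says the series, first, only, none or still open, it means among the compounds named here.

Of the compounds shown here, two have been measured in a physicochemical assay for solubility, read by HPLC, measured as thermodynamic solubility, with a stated time of 4 h, at pH 6.8; a lower number here means a less soluble compound, a higher number a more soluble compound. Compound 1, with the structure `Cc1ccc(Oc2cc3c(cn2)nc(COc2cccc(C(=O)O)c2)n3C)cc1`, gives 360 ug/mL in this assay. Compound 2, with the structure `Cn1c(COc2cccc(C(=O)O)c2)nc2ccc(Oc3cccc(Cl)n3)cc21`, gives 7.7 ug/mL in this assay. Among the compounds with values here, compound 2 thus stands at the lower of the two numbers, and the gap to compound 1 lies beyond the scatter; the two compounds differ in more than one place, so no single step connects them.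

Compound 3, with the structure `Cn1c(COc2cccc(C(=O)O)c2)nc2ccc(Oc3cc(Cl)ccn3)cc21`, has not yet been measured. It differs from compound 2 in one place: 4-chloropyridin-2-yl in place of 6-chloropyridin-2-yl on an oxygen on an aromatic ring. The two have the same atoms, joined differently, so the change is small in size and keeps the count of hydrogen-bond donors and acceptors unchanged. Within the data shown here, with no measured pair of this kind to lean on, the step from compound 2 to compound 3 is expected to stay within the scatter, or at most a little beyond it in either direction, giving a 1.3-fold higher number from compound 2 to compound 3 (0.11 log units; within the scatter) as the estimate. Compound 3 is therefore estimated at 10 ug/mL in this assay, with a range from 3 ug/mL to 35 ug/mL.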

Compound 3, solubility: 11 ug/mL
Beside the measured number, compound 3's estimate is 1.1-fold (0.04 log units) below it; the measured number falls inside the stated range.
By their numbers in this assay, from the lowest: compounds 2 and 3 (each within the scatter of the next); then compound 1.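

Within the data shown here, putting 4-chloropyridin-2-yl in place of 6-chloropyridin-2-yl gives a 1.4-fold higher number from compound 2 to compound 3 (0.15 log units; within the scatter) in this assay, and this is the first direct reading of any change at this place, on an oxygen on an aromatic ring. It shows that, for this one pair, the two placements of the chlorine cannot be told apart in this measurement, even though the atoms are joined differently; the group that leaves and the group that enters have the same heavy atoms and the same counts of hydrogen-bond donors and acceptors. No supporting measurement accompanies the result, so it stands as a plain observation about these two compounds, with nothing on hand to explain it.

All the groups shown at this place carry a chlorine, so what a methoxy group, a nitrile or a dimethylamino group would do in its stead remains open. Also open, going by these compounds, is whether the same move of the chlorine would read the same on another core, such as the core of compound 1, or in this assay at another pH.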